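Replacing 4-methylphenyl with 3,5-difluorophenyl on the amide

This account rests on a few compounds, and the source may have more. Where it says the series, first, only, none or still open, it means among the compounds named here.

Among the measured compounds shown here, compound 1 `Cc1ccc(C(=O)Nc2cccc(-c3oc4cc(-c5ccc(F)cc5)ccc4c(=O)c3O)c2)cc1` gives 12900 nM in a functional assay on GTL 16 cells for antiproliferative activity against GTL 16 cell line (Homo sapiens), read by CCK-8 assay, with a stated time of 72 h (a lower number here means a stronger inhibitor, a higher number a weaker inhibitor), and it stands beside compound 2 `O=C(Nc1cccc(-c2oc3cc(-c4ccc(F)cc4)ccc3c(=O)c2O)c1)c1ccc(Cl)cc1`, the only other measured compound, which gives 9140 nM in this assay, a difference within the scatter. For the measured compounds named here, the one measured step at this position is a 1.4-fold lower number from compound 1 to compound 2 (0.15 log units; within the scatter), a chloro in place of methyl on an aromatic carbon. Compound 3 `O=C(Nc1cccc(-c2oc3cc(-c4ccc(F)cc4)ccc3c(=O)c2O)c1)c1cc(F)cc(F)c1` differs from compound 1 by 3,5-difluorophenyl in place of 4-methylphenyl on a carbonyl carbon. Because a 1.4-fold lower number from compound 1 to compound 2 (0.15 log units; within the scatter) stayed within the scatter, no step beyond the scatter is expected for this change either. Compound 3 is therefore estimated at 10000 nM, between 3500 nM and 30000 nM. The expected step is a 1.3-fold lower number from compound 1 to compound 3 (0.11 log units; within the scatter).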

Compound 3, half-maximal inhibitory concentration: 7410 nM
Compound 3: middle estimate off by 1.3-fold (0.13 log units), on the high side; the range from low to high includes it.
By their numbers in this assay, from the lowest: compounds 3, 2 and 1 (each within the scatter of the next).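

In this assay the change to 3,5-difluorophenyl on the carbonyl carbon gives a 1.7-fold lower number from compound 1 to compound 3 (0.24 log units; within the scatter) and a 1.2-fold lower number from compound 2 to compound 3 (0.09 log units; within the scatter) so a third aryl group joins the first two without leaving the scatter. Across 4-methylphenyl, 4-chlorophenyl and 3,5-difluorophenyl the position therefore shows no separation between compounds. No measurement on hand offers an explanation for this.

As far as these compounds go, it remains open whether a different kind of group on this carbonyl carbon, such as an aminomethylphenyl, a carboxyphenyl or a longer alkyl chain, would move the number beyond the scatter.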